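The source may report more compounds than this note shows. Statements on the series, on what has been measured and on what is new or still open speak of the compounds shown alone.

Compound 2 `CC(C)n1c(/C=C2\SC(=O)N(CC(=O)N3CCCC3)C2=O)nc2ccccc21` is the starting point of this comparison. In a functional assay on MDA-MB-231 cells (Homo sapiens) for inhibition, read by MTT assay, with a stated time of 48 h (a lower number here means a stronger inhibitor, a higher number a weaker inhibitor), compound 2 gives only a limit, > 50000 nM, not a number. Compound 3 `CCn1c(/C=C2\SC(=O)N(CC(=O)Nc3cc(C(C)(C)C)on3)C2=O)nc2ccccc21` likewise reaches only a limit in this assay, > 50000 nM. For the measured compounds named here, compound 1 `Cn1c(/C=C2\SC(=O)N(CC(=O)Nc3cc(C(C)(C)C)on3)C2=O)nc2ccccc21` is the one compound with a number in this assay, 33800 nM. Going by the values given here, the step of an at least 1.4-fold higher number from compound 1 to compound 3 (0.17 log units; that floor lies within the scatter) is the only measured step. Thus compound 2 sits where most of these compounds sit, namely at the limit of > 50000 nM in this assay, at which 2 of the 3 values shown sit.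

Compound 4 `CC1CN(C(=O)CN2C(=O)S/C(=C\c3nc4ccccc4n3C(C)C)C2=O)CC(C)O1` differs from compound 2 in one place: 2,6-dimethylmorpholin-4-yl in place of pyrrolidin-1-yl on a carbonyl carbon. Among the compounds with values here, no measured step touches this carbonyl carbon; the step from compound 1 to compound 3 concerns the saturated chain carbon bound to an aromatic nitrogen and does not bear on the change from pyrrolidin-1-yl to 2,6-dimethylmorpholin-4-yl. Within the data shown here, with compound 2 at a limit and no related step to lean on, the step that the limit leaves unreadable from compound 2 to compound 4 is expected to be none beyond the scatter, and compound 4 is estimated at 60000 nM, within 25000 nM to 150000 nM, most likely again reported only as a limit.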

Compound 4, half-maximal inhibitory concentration: > 50000 nM
Compound 4 was reported as a limit; the forecaster's own chance of this, stated with the estimate: 70%; the middle value is on the limit's open side.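

Compound 2 and compound 4 are both reported only as limits, so no step between them can be read, and compound 4 stands with compound 2: the limit of > 50000 nM in this assay, at which 3 of the 4 values shown sit.

The compounds shown leave open whether 2,6-dimethylmorpholin-4-yl in place of pyrrolidin-1-yl on a carbonyl carbon changes the inhibition at all.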